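The compounds below may be only part of what the source reports. "The series", "measured", "known", "first", "only" and "open" are said of these compounds alone.

Measured in a functional assay on HCT-116 cells (Homo sapiens) for inhibition, read by sulforhodamine B assay, with a stated time of 48 h, tested at 50 uM; a lower number here means less inhibition of growth, a higher number more inhibition of growth at the concentration tested:
Compound 1, `COc1ccc(/C=C/C(=O)/C=C/c2ccc(OCc3cn(CCCCCOc4cc(=O)oc5ccccc45)nn3)c(OC)c2)cc1`: 35%
Compound 2, `COc1ccccc1/C=C/C(=O)/C=C/c1ccc(OCc2cn(CCCCOc3cc(=O)oc4ccccc34)nn2)c(OC)c1`: 43%

Within the data shown here, compound 2 holds the larger of the two numbers recorded in this assay, but compound 1, its only neighbour, lies within the usual scatter of it, so the two compounds cannot be told apart on these data. Compound 1 and compound 2 differ from each other in more than one place, so no single step between them is shown.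

Compound 3, `COc1cc(/C=C/C(=O)/C=C/c2ccccc2)ccc1OCc1cn(CCCCOc2cc(=O)oc3ccccc23)nn1`, has not yet been measured in this assay. It differs from compound 2 in one place: hydrogen in place of methoxy on an aromatic carbon. Among the measured compounds shown here, no measured pair shows this change, so its effect is unknown from the data at hand. Both measured compounds fall in a narrow band, and nothing in the numbers gives ground to expect compound 3 to leave it. The step of a number 5 percentage points lower from compound 2 to compound 3 (within the scatter) is expected to be small, a slight fall or none beyond the scatter. Compound 3 is therefore estimated at 38%, within a range from 20% to 58%.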

Compound 3, percent growth inhibition at one concentration: 34%
For compound 3 the middle estimate is 4 percentage points above the measured one, and the stated range covers the measured number.
By their numbers in this assay, from the lowest: compounds 3, 1 and 2 (each within the scatter of the next).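

In this assay, among these compounds, the pair of compound 2 and compound 3 is the first to isolate the change from 2-methoxyphenyl to phenyl, and it reads a number 9 percentage points lower from compound 2 to compound 3 (within the scatter) and so gives no sign that this methoxy group matters at the concentration tested. At this place, on an aromatic carbon ortho to a large group, hydrogen and methoxy therefore cannot be told apart by growth inhibition, although a single pair at a single concentration cannot show that the two are equivalent in general. No measured property or other supporting data accompany this result, and the step stands without an explanation.

On these data alone, whether a hydroxyl group, a chlorine atom or a dimethylamino group at this place would give a step beyond the scatter remains open. As far as these compounds go, it is also open whether the change from methoxy to hydrogen would read the same way in a compound with a longer chain, or whether any difference between these compounds would appear at other concentrations.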